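Replacing the phenylethenyl of compound 3 with a methoxyphenyl

This account rests on a few compounds, and the source may have more. Where it says the series, first, only, none or still open, it means among the compounds named here.

Three hydrazones sharing one core have been measured in a physicochemical assay for lipophilicity, measured as octanol-water partition; on this read-out lower numbers stand for lower lipophilicity and higher numbers for higher lipophilicity. Compound 1 `O=C(COc1cccc2ccccc12)N/N=C/c1cccc(O)c1` gives 3.73, and compound 2 `O=C(COc1cccc2ccccc12)N/N=C/c1ccccc1O` gives 3.73, with no change at the digits printed from compound 1 to compound 2 (within the scatter). Compound 3 `O=C(COc1cccc2ccccc12)N/N=C/C=C/c1ccccc1` gives 4.43 and stands highest of the three, with a number 0.70 log units higher from compound 1 to compound 3 (beyond the scatter) and a number 0.70 log units higher from compound 2 to compound 3 (beyond the scatter).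

Compound 4 `COc1ccc(/C=N/NC(=O)COc2cccc3ccccc23)cc1` is the next step from compound 3: 4-methoxyphenyl in place of 2-phenylethenyl on a carbon with a double bond to nitrogen. The two measured steps that bear on it both end at compound 3, each trading a hydroxyphenyl for the 2-phenylethenyl, and each was a modest rise. For the measured compounds named here, the step to compound 4 runs the other way from that group, but what enters is a 4-methoxyphenyl, not a hydroxyphenyl, so the earlier steps are only a partial guide. She therefore expects a modest fall, a number 0.33 log units lower from compound 3 to compound 4 (beyond the scatter), landing between the hydroxyphenyl pair and compound 3. Her estimate for compound 4 in this assay is 4.1, with a range from 3.6 to 4.6.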

Compound 4, partition coefficient: 3.77
Estimate against measurement, compound 4: 0.33 log units above, within the range that was stated.
By their numbers in this assay, from the lowest: compounds 1, 2 and 4 (each within the scatter of the next); then compound 3.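

In this assay the change gives a number 0.66 log units lower from compound 3 to compound 4 (beyond the scatter) and so shows that a rise at this carbon with a double bond to nitrogen is not kept by every replacement of a hydroxyphenyl. For the compounds shown here, the 4-methoxyphenyl instead stands level with both hydroxyphenyl groups, with a number 0.04 log units higher from compound 2 to compound 4 (within the scatter) and a number 0.04 log units higher from compound 1 to compound 4 (within the scatter), leaving the 2-phenylethenyl of compound 3 as the only group here that stands apart. Nothing available accounts for that separation.

As far as these compounds go, whether the separation depends on the double bond of the 2-phenylethenyl stays open, and a saturated 2-phenylethyl chain or a longer chain would bear on that. Also open, from the compounds shown here alone, is whether an amine or a carboxylic acid on the phenyl ring would stay level with compounds 1, 2 and 4.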